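A few compounds are considered here, and "the series" means these few. Any claim that something is new, unique, unknown or untested is made for them only; others in the source may bear on it.

For the measured compounds named here, compound 2 `C=CC(=O)Nc1cc2c(N3CCc4ccccc43)ncnc2cc1O[C@@H]1CCOC1` gives 5950 nM in a functional assay on MCF7 cells (Homo sapiens) for antiproliferative activity, read by MTT assay, with a stated time of 72 h (a higher number here means a weaker inhibitor, a lower number a stronger inhibitor), the lowest of the three numbers measured so far, though it sits within the scatter of compound 1 `C=CC(=O)Nc1cc2c(N3CCc4ccccc43)ncnc2cc1OC`, which gives 11700 nM, and of compound 3 `COc1cc2ncnc(N3CCc4ccccc43)c2cc1NC(=O)/C=C/CN1CCN(C)CC1`, which gives 6430 nM. Compound 4 `O=C(/C=C/CN1CCCCC1)Nc1cc2c(N3CCc4ccccc43)ncnc2cc1O[C@@H]1CCOC1` differs from compound 2 by 3-(piperidin-1-yl)prop-1-en-1-yl in place of vinyl on a carbonyl carbon. The measured step that bears most directly on this is a 1.8-fold lower number from compound 1 to compound 3 (0.26 log units; within the scatter), a change on the same carbonyl carbon; the other measured step, a 2.0-fold lower number from compound 1 to compound 2 (0.29 log units; within the scatter), concerns another place on the core. On that basis only a modest lowering, not beyond the scatter, is expected for compound 4, an estimated 1.5-fold lower number from compound 2 to compound 4 (0.17 log units; within the scatter). Compound 4 is therefore expected to give about 4000 nM in this assay, within a range of 1500 nM to 11000 nM.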

Compound 4, half-maximal inhibitory concentration: 1890 nM
Compound 4: the middle estimate sits 2.1-fold (0.33 log units) above what was measured; the measured number falls inside the stated range.
By their numbers in this assay, from the lowest: compound 4; then compounds 2, 3 and 1 (each within the scatter of the next).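

In this assay, a change on the carbonyl carbon now gives a step beyond the scatter, a 3.1-fold lower number from compound 2 to compound 4 (0.50 log units; beyond the scatter), whereas the earlier change there, a 1.8-fold lower number from compound 1 to compound 3 (0.26 log units; within the scatter), stayed within it. So the vinyl group at this place can be replaced by the larger 3-(piperidin-1-yl)prop-1-en-1-yl with a lower number, not merely an unchanged one. Nothing measured here explains this step. The two steps differ in both the amine and the group on the oxygen, so the compounds shown cannot separate those two differences. As far as these compounds go, how a morpholine or a dimethylamine in place of the piperidine would read remains open.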